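Rearranging the side chain of compound 2

A few compounds are considered here, and "the series" means these few. Any claim that something is new, unique, unknown or untested is made for them only; others in the source may bear on it.

Values in a functional assay on Caco-2 cells (Homo sapiens) for antiproliferative activity, read by sulforhodamine B assay, with a stated time of 48 h (on this read-out higher numbers stand for weaker inhibition and lower numbers for stronger inhibition), for the compounds measured so far:

- Compound 1 (`COc1cc(NC(C)CCCN2C(=O)CN(C(C)=O)C2(C)C)c2ncccc2c1`): 60000 nM
- Compound 2 (`COc1cc(NC(C)CCCNC(=O)CN2C(=O)[C@H](C)NC2(C)C)c2ncccc2c1`): 58000 nM

Compound 2 gives 58000 nM in this assay and so stands level with compound 1 at 60000 nM within the usual scatter of repeated measurements.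

Compound 3 (`COc1cc(NC(C)CCCNC(=O)C2CCCN2C(=O)[C@@H](C)N)c2ncccc2c1`) is built from the same atoms as compound 2, joined differently (1-((1-aminoethyl)carbonyl)pyrrolidin-2-yl in place of (2,2,4-trimethyl-5-oxoimidazolidin-1-yl)methyl on a carbonyl carbon): 1-((1-aminoethyl)carbonyl)pyrrolidin-2-yl stands in place of (2,2,4-trimethyl-5-oxoimidazolidin-1-yl)methyl on a carbonyl carbon.

For the measured compounds named here, no measured pair here isolates a change of this kind, so the expectation rests on thin ground. Compound 1 at 60000 nM and compound 2 at 58000 nM show only that two different side chains on the shared core can give values within the scatter of each other.

What is expected in this assay is a 1.2-fold lower number from compound 2 to compound 3 (0.06 log units; within the scatter) and so nothing beyond the scatter. Compound 3 is expected at 50000 nM (estimated range 15000 nM to 120000 nM).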

Compound 3, half-maximal inhibitory concentration: 64000 nM
Beside the measured number, compound 3's estimate is 1.3-fold (0.11 log units) below it; the range from low to high includes it.
By their numbers in this assay, from the lowest: compounds 2, 1 and 3 (each within the scatter of the next).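

In this assay, for the compounds shown here, putting 1-((1-aminoethyl)carbonyl)pyrrolidin-2-yl in place of (2,2,4-trimethyl-5-oxoimidazolidin-1-yl)methyl on a carbonyl carbon gives a 1.1-fold higher number from compound 2 to compound 3 (0.04 log units; within the scatter) and is the first comparison here in which the two compounds differ in one place only. The two groups have the same heavy-atom, donor and acceptor counts, but one has a five-membered non-aromatic ring with 2 hetero atoms and the other has a five-membered non-aromatic ring with 1 hetero atom, so at this place, this rearrangement of the same atoms leaves the number within the scatter. Nothing measured here bears on why the read-out stays level across this change.

Going by these compounds, one swap of two groups with the same atoms cannot show whether this place tolerates changes in general, so it remains open whether other groups would also stay within the scatter. A carboxylic acid on the carbonyl carbon, or a piperidine ring in place of the pyrrolidine, would test whether the number can be moved away from that of compound 2 by more than the scatter.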